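Clearance in liver microsomes: from compound 2 to compound 3

A few compounds are considered here, and "the series" means these few. Any claim that something is new, unique, unknown or untested is made for them only; others in the source may bear on it.

Measured so far:
compound 1 `CN1C[C@H](C(=O)Nc2ccccc2)[C@@H](c2ccc(/C=C/C(=O)Nc3ccccc3N)cc2)C1`: 7 mL/min/kg
compound 2 `CN1C[C@H](C(=O)Nc2ccc(Br)cc2)[C@@H](c2ccc(/C=C/C(=O)Nc3ccccc3N)cc2)C1`: 3 mL/min/kg

Both compounds were run in an in vitro ADME assay on microsomes from liver (Homo sapiens) for pharmacokinetics, read by LC-MS, with a stated time of 10 min, tested at 1 uM; a higher number here means faster removal of the compound, a lower number slower removal. Compound 1 gives 7 mL/min/kg, and compound 2 gives 3 mL/min/kg. For the measured compounds named here, of the two numbers, compound 2 stands lowest; its only neighbour is compound 1, and the change between them, bromo in place of hydrogen on an aromatic carbon, brought a 2.3-fold lower number from compound 1 to compound 2 (0.37 log units; beyond the scatter).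

Compound 3 `CN1C[C@H](C(=O)Nc2ccccc2F)[C@@H](c2ccc(/C=C/C(=O)Nc3ccccc3N)cc2)C1` has not yet been measured in this assay. It differs from compound 2 in one place: 2-fluorophenyl in place of 4-bromophenyl on an amide-type nitrogen.

Going by the values given here, only one measured step bears on this change, and only partly. That step, a 2.3-fold lower number from compound 1 to compound 2 (0.37 log units; beyond the scatter), shows what bromo in place of hydrogen did; nothing measured shows what a fluoro does at this ring, nor at the position it takes here. With the bromine leaving, the number for compound 3 is expected to drift back toward that of compound 1, so the step of a 1.7-fold higher number from compound 2 to compound 3 (0.22 log units; within the scatter) is expected, upward, though it may well stay within the scatter. Compound 3 is therefore estimated at 5 mL/min/kg, within a range of 2.5 mL/min/kg to 10 mL/min/kg.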

Compound 3, clearance: 10 mL/min/kg
Beside the measured number, compound 3's estimate is 2.0-fold (0.30 log units) below it; the measured number falls inside the stated range.
By their numbers in this assay, from the lowest: compound 2; then compounds 1 and 3 (each within the scatter of the next).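

In this assay, the group on the amide-type nitrogen proves able to move the number in the upward direction as well: replacing 4-bromophenyl with 2-fluorophenyl gives a 3.3-fold higher number from compound 2 to compound 3 (0.52 log units; beyond the scatter) and so undoes the earlier drop seen with bromo. Adding a fluoro to this ring gives a 1.4-fold higher number from compound 1 to compound 3 (0.15 log units; within the scatter) and so leaves compound 3 not distinguishable from compound 1, which makes compound 2 the only one of the three that stands apart, with steps beyond the scatter to both others. Nothing measured here accounts for this difference between the two halogen-bearing compounds.

The step from 4-bromophenyl to 2-fluorophenyl changes the halogen and its place on the ring together, so the compounds shown cannot say which of the two matters for the number. Also open, on these data alone, is whether a group other than a halogen on this ring, such as a methoxy group, a nitrile or an amine, would bring the number down as bromo did or leave it where the hydrogen and the fluoro compounds stand.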